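The source may hold more compounds than are shown below. What is called first, only, known or untested is meant among the compounds shown, and "the series" means these compounds.

Measured compounds:
- compound 1 `COc1cc(Oc2cccc(Nc3ccccc3)c2)cc(OC)c1CNCc1ccc(F)cc1` gives 2650 nM in a functional assay on DLD-1 cells (Homo sapiens) for inhibition, read by MTT assay, with a stated time of 72 h; on this read-out lower numbers stand for stronger inhibition and higher numbers for weaker inhibition
- compound 2 `COc1cc(Oc2cccc(Nc3ccccc3)c2)cc(OC)c1CNC(C)C` reaches only the limit of this assay, > 20000 nM

Compound 2 therefore stands at the weak end of the numbers shown: its value is a limit of this assay and not a measured number, as the limit of > 20000 nM in this assay, at which 1 of the 2 values shown sits, records. Compound 3 `COc1cc(Oc2cccc(Nc3ccccc3)c2)cc(OC)c1CNCc1ccc(O)cc1` is not yet measured. It differs from compound 2 by 4-hydroxybenzyl in place of isopropyl on an amine nitrogen. Within the data shown here, the only measured step that bears on this change is the one between compound 1 and compound 2, in which isopropyl replaced 4-fluorobenzyl and the number rose by an at least 7.5-fold higher number from compound 1 to compound 2 (0.87 log units; beyond the scatter). The change from compound 2 to compound 3 runs the other way, restoring a benzyl group on the amine nitrogen, here carrying a hydroxy group instead of fluorine. A step of a similar size downward, beyond the scatter, is therefore expected, with compound 3 expected to land near the value of compound 1. The estimated step from compound 2 to compound 3 is an at least 5.7-fold lower number from compound 2 to compound 3 (0.75 log units; beyond the scatter). For compound 3 the expected value in this assay is 3500 nM, within an expected range of 1000 nM to 15000 nM.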

Compound 3, half-maximal inhibitory concentration: 2690 nM
Estimate against measurement, compound 3: 1.3-fold (0.11 log units) above; low and high end bracket the measured number.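

In this assay, replacing isopropyl on the amine nitrogen with 4-hydroxybenzyl gives an at least 7.4-fold lower number from compound 2 to compound 3 (0.87 log units; beyond the scatter), so a second benzyl-type group, and not only the 4-fluorobenzyl group, goes with a measurable value at this position. The true size of that step cannot be fixed because compound 2 sits at a limit of the assay and not at a measured number: the limit of > 20000 nM in this assay, at which 1 of the 3 values shown sits. Hydroxy in place of fluoro on the aromatic carbon gives a 1.0-fold higher number from compound 1 to compound 3 (0.01 log units; within the scatter), so these two benzyl compounds cannot be told apart, and across the three compounds the clear difference lies between isopropyl and the two substituted benzyl groups, not between the hydroxy and the fluoro group.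

On these data alone, whether a plain benzyl group, or a methoxy group or carboxylic acid on the benzyl ring, would give a similar value remains open, as does the effect of a longer chain such as 2-phenylethyl on the nitrogen. As far as these compounds go, it is also open whether a ring is needed at all, or whether a saturated ring such as cyclohexyl or a longer alkyl chain such as n-hexyl could take the place of the aromatic ring.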